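Sulfonamide series: unsubstituted benzyl analogue of compound 2

A few compounds are considered here, and "the series" means these few. Any claim that something is new, unique, unknown or untested is made for them only; others in the source may bear on it.

Compound 1 `O=S(=O)(NCCNCc1ccc(-c2ccccc2)cc1)c1cc(C(F)(F)F)cc(C(F)(F)F)c1`: 2800 nM
Compound 2 `O=S(=O)(NCCCNCc1ccc(Cl)c(C(F)(F)F)c1)c1cc(C(F)(F)F)cc(C(F)(F)F)c1`: 9600 nM

In a functional assay on ASPC1 cells (Homo sapiens) for inhibition, read by MTT assay, with a stated time of 72 h (a lower number here means a stronger inhibitor of growth, a higher number a weaker inhibitor of growth), compound 2 gives 9600 nM, the highest of the two numbers; compound 1 gives 2800 nM. Compound 3 `O=S(=O)(NCCCNCc1ccccc1)c1cc(C(F)(F)F)cc(C(F)(F)F)c1` carries phenyl in place of 4-chloro-3-(trifluoromethyl)phenyl on a saturated chain carbon bound to an amine nitrogen. For the measured compounds named here, no pairwise step between measured compounds is available to guide this change. The larger aryl group of compound 1 goes with the lower number, and compound 3 strips the benzyl group bare, so a modest rise in the number, likely beyond the scatter, is expected, a 1.7-fold higher number from compound 2 to compound 3 (0.22 log units; within the scatter). Compound 3 is estimated at 16000 nM, range 5000 nM to 45000 nM.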

Compound 3, concentration for 50% growth inhibition: 13000 nM
Estimate against measurement, compound 3: 1.2-fold (0.09 log units) above, and the stated range covers the measured number.
By their numbers in this assay, from the lowest: compound 1; then compounds 2 and 3 (each within the scatter of the next).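

In this assay, for the compounds shown here, phenyl in place of 4-chloro-3-(trifluoromethyl)phenyl on a saturated chain carbon bound to an amine nitrogen gives the first single-place step (a 1.4-fold higher number from compound 2 to compound 3 (0.13 log units; within the scatter)). At this position, the chlorine and trifluoromethyl substituents can therefore be removed together without a shift beyond the scatter. No measured evidence bears on this result. Still open, going by these compounds, is whether a carboxylic acid on this phenyl would move the number beyond the scatter. Compound 1 differs from compound 2 in both chain and aryl group, leaving the contribution of each unresolved.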